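A few compounds are considered here, and "the series" means these few. Any claim that something is new, unique, unknown or untested is made for them only; others in the source may bear on it.

Measured so far:
- compound 1, `Cc1ccc(-c2nnc(N3CCN(C(=O)CN4CCN(c5ccccc5Cl)CC4)CC3)nc2-c2ccc(C)cc2)cc1`: 859000 nM
- compound 2, `O=C(CN1CCN(c2ccccc2Cl)CC1)N1CCN(c2nnc(-c3ccc(Cl)cc3)c(-c3ccc(Cl)cc3)n2)CC1`: 396000 nM

In a functional assay on MCF7 cells (Homo sapiens) for cytotoxicity, read by MTT assay, with a stated time of 24 h (on this read-out higher numbers stand for weaker inhibition and lower numbers for stronger inhibition), compound 2 gives the lowest of the two numbers; compound 1 sits above it, and that gap is beyond the scatter. Compound 3, `COc1ccc(N2CCN(CC(=O)N3CCN(c4nnc(-c5ccc(Cl)cc5)c(-c5ccc(Cl)cc5)n4)CC3)CC2)cc1`, differs from compound 2 by 4-methoxyphenyl in place of 2-chlorophenyl on an amine nitrogen in a ring. Within the data shown here, no measured pair shows this change, so its effect is unknown. Both measured numbers are very high, and the change is small against the shared core, so a step from compound 2 to compound 3 of no more than the scatter, in either direction, is expected. Compound 3 is estimated at 420000 nM, with a range from 150000 nM to 1100000 nM, meaning an expected step of a 1.1-fold higher number from compound 2 to compound 3 (0.03 log units; within the scatter).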

Compound 3, half-maximal inhibitory concentration: > 809000 nM
Compound 3 gave a limit, no number; the forecaster's own chance of this, stated with the estimate: 15%; middle value at least 1.9-fold (0.28 log units) away from the limit.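

In this assay, compound 3 gave only a limit, > 809000 nM, and not a number. Even so, this is the first measured change at this position, and 4-methoxyphenyl in place of 2-chlorophenyl gives an at least 2.0-fold higher number from compound 2 to compound 3 (0.31 log units; beyond the scatter), so the group on this ring nitrogen does affect the read-out. The true size of the step remains unknown, and the step rests on a limit: the limit of > 809000 nM in this assay, at which 1 of the 3 values shown sits.

The compounds shown leave open whether losing the chlorine or gaining the methoxy accounts for the step. A plain phenyl or a 4-chlorophenyl at this place would help separate the two.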